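Pyridyl amide variation on the shared core

The source may hold more compounds than are shown below. What is called first, only, known or untested is meant among the compounds shown, and "the series" means these compounds.

Measured so far in a functional assay on A549 cells (Homo sapiens) for antiproliferative activity, read by MTT assay, with a stated time of 72 h; on this read-out higher numbers stand for weaker inhibition and lower numbers for stronger inhibition:
- compound 1 `COc1cc(F)c(NC(=O)c2ccncc2)cc1Nc1nccc(-c2cn(C)c3ccccc23)n1`: 4200 nM
- compound 2 `COc1cc(F)c(NC(=O)c2ccnc(O)c2)cc1Nc1nccc(-c2cn(C)c3ccccc23)n1`: 11700 nM
- compound 3 `COc1ccc(C(=O)Nc2cc(Nc3nccc(-c4cn(C)c5ccccc45)n3)c(OC)cc2F)nc1`: 8200 nM

Compound 3 sits between compound 1 and compound 2 on this assay, and both gaps are small: a 2.0-fold higher number from compound 1 to compound 3 (0.29 log units; within the scatter) and a 1.4-fold lower number from compound 2 to compound 3 (0.15 log units; within the scatter) are each within the scatter. Within the data shown here, only the step from compound 1 to compound 2, which puts a hydroxy in place of hydrogen on an aromatic carbon, reaches beyond the scatter: a 2.8-fold higher number from compound 1 to compound 2 (0.44 log units; beyond the scatter).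

Compound 4 `COc1cc(F)c(NC(=O)c2ccccn2)cc1Nc1nccc(-c2cn(C)c3ccccc23)n1` differs from compound 3 in one place: hydrogen in place of methoxy on an aromatic carbon. Among the measured compounds shown here, no measured pair removes a methoxy from this ring, so the step has no direct precedent. The nearest comparison is the pyridyl swap in a 2.0-fold higher number from compound 1 to compound 3 (0.29 log units; within the scatter), which stayed within the scatter, and the hydroxy addition in a 2.8-fold higher number from compound 1 to compound 2 (0.44 log units; beyond the scatter), which was only modest. Taking away a small group from the amide ring is therefore expected to move this assay little, if anything slightly toward the number of compound 1.

For compound 4 the expected step is a 1.4-fold lower number from compound 3 to compound 4 (0.14 log units; within the scatter), and the estimate is 6000 nM, in the range 2500 nM to 15000 nM.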

Compound 4, half-maximal inhibitory concentration: 7980 nM
Compound 4: the middle estimate sits 1.3-fold (0.12 log units) below what was measured; measured number inside the range.
By their numbers in this assay, from the lowest: compounds 1, 4, 3 and 2 (each within the scatter of the next, the first and the last beyond it).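

In this assay the methoxy two atoms from the ring nitrogen and para to a large group can be exchanged for hydrogen on the pyridin-2-yl amide with no readable effect (a 1.0-fold lower number from compound 3 to compound 4 (0.01 log units; within the scatter)), so this position shows no sensitivity between these two groups. The unsubstituted pyridin-2-yl amide also stays within the scatter of the two compounds that lie beyond the scatter of each other (a 1.9-fold higher number from compound 1 to compound 4 (0.28 log units; within the scatter); a 1.5-fold lower number from compound 2 to compound 4 (0.17 log units; within the scatter)), which means that exchanging pyridin-4-yl for pyridin-2-yl gives no readable step and compound 4 cannot be placed nearer to either end. No supporting measurement is available to explain this flat result.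

Going by these compounds, whether any group at this position can move the number stays open, since an amine, a carboxylic acid or a longer chain such as ethoxy would show whether the flat result extends beyond methoxy and hydrogen. Among these compounds, also open is whether hydroxy on the pyridin-2-yl ring would repeat the only step beyond the scatter so far, seen on the pyridin-4-yl ring (a 2.8-fold higher number from compound 1 to compound 2 (0.44 log units; beyond the scatter)).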